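Swapping the aryl group: from methoxyphenyl to dichlorophenyl

The compounds below may be only part of what the source reports. "The series", "measured", "known", "first", "only" and "open" are said of these compounds alone.

Compound 2 `COc1ccc(-c2cc(C(=O)Nc3ccc(Oc4ccnc5cc(OCCCN6CCCCC6)c(OC)cc45)c(F)c3)c3cc(F)ccc3n2)cc1` holds the higher of the two numbers measured in a functional assay on HT-29 cells (Homo sapiens) for cytotoxicity, read by MTT assay, with a stated time of 72 h (on this read-out lower numbers stand for stronger inhibition and higher numbers for weaker inhibition), where compound 2 gives 600 nM, while compound 1 `COc1cc2c(Oc3ccc(NC(=O)c4cc(-c5ccccc5)nc5ccc(F)cc45)cc3F)ccnc2cc1OCCCN1CCCCC1` gives 120 nM. Within the data shown here, the one measured step, a 5.0-fold higher number from compound 1 to compound 2 (0.70 log units; beyond the scatter), is the only one that bears on compound 3 `COc1cc2c(Oc3ccc(NC(=O)c4cc(-c5ccc(Cl)cc5Cl)nc5ccc(F)cc45)cc3F)ccnc2cc1OCCCN1CCCCC1`, which carries 2,4-dichlorophenyl in place of 4-methoxyphenyl on an aromatic carbon. That change undoes the methoxy of compound 2 and brings in a different aryl, so the number for compound 3 is expected to move back toward compound 1, by a 3.0-fold lower number from compound 2 to compound 3 (0.48 log units; beyond the scatter) in this assay. Compound 3 is therefore estimated at 200 nM, between 60 nM and 700 nM.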

Compound 3, half-maximal inhibitory concentration: 530 nM
Compound 3: the middle estimate sits 2.7-fold (0.42 log units) below what was measured, and the stated range covers the measured number.
By their numbers in this assay, from the lowest: compound 1; then compounds 3 and 2 (each within the scatter of the next).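

In this assay, the 2,4-dichlorophenyl and 4-methoxyphenyl groups cannot be told apart at this position, with a 1.1-fold lower number from compound 2 to compound 3 (0.05 log units; within the scatter) at this reading. The plain phenyl of compound 1 stays ahead of the dichlorinated ring, with a 4.4-fold higher number from compound 1 to compound 3 (0.65 log units; beyond the scatter) on that step, so among the compounds shown the higher number is not particular to methoxy. Nothing available explains this result. Left open is whether a phenyl ring bearing a single chlorine, a fluorine or a dimethylamino group would read like phenyl or like these two substituted rings.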